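A phenyl group added to compound 2

The compounds below may be only part of what the source reports. "The series", "measured", "known", "first", "only" and "open" are said of these compounds alone.

Measured so far in an ADME assay on HEK-293T cells (Homo sapiens) for cytotoxicity, read by luminescence and CellTiter-Glo, with a stated time of 24 h; a lower number here means that less compound is tolerated, a higher number that more compound is tolerated:
Compound 1 `CCCNC(=O)C1CCN(C(=O)c2cc3ccsc3n2Cc2ccc(OC)cc2)CC1` gives 23400 nM
Compound 2 `CCCNC(=O)[C@@H]1C[C@H]2CCC[C@@H](C1)[C@@H]2NC(=O)c1cc2scnc2n1Cc1ccc(OC)cc1` gives > 25000 nM

Compound 2 gives only a limit, > 25000 nM and no number. Compound 3 `CCCNC(=O)[C@@H]1C[C@H]2CCC[C@@H](C1)[C@@H]2NC(=O)c1cc2sc(-c3ccccc3)nc2n1Cc1ccc(OC)cc1` has not yet been measured. It differs from compound 2 in one place phenyl in place of hydrogen on an aromatic carbon with phenyl in place of hydrogen on an aromatic carbon, next to the ring nitrogen and next to the ring sulfur. Among the measured compounds shown here, no measured pair shows what such a change does. A small step toward less compound tolerated is expected, estimated as an at least 1.2-fold lower number from compound 2 to compound 3 (0.09 log units; that floor lies within the scatter) in this assay and not firmly separated from the scatter. Compound 3 is estimated at 20000 nM with an expected range from 9000 nM to 30000 nM when measured.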

Compound 3, half-maximal cytotoxic concentration: > 100000 nM
Compound 3: a limit, no number; the forecaster's own chance of this, stated with the estimate: 50%; middle value at least 5.0-fold (0.69 log units) from the limit.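

In this assay, among the compounds shown here, compound 2 and compound 3 both give only limits, so no step between them can be read. The compounds shown leave open whether phenyl in place of hydrogen changes the tolerated concentration, and by how much.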